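The source may hold more compounds than are shown below. What is called first, only, known or untested is meant among the compounds shown, and "the series" means these compounds.

In a functional assay on HT-29 cells (Homo sapiens) for cytotoxicity, read by MTT assay, with a stated time of 72 h (on this read-out higher numbers stand for weaker inhibition of growth and lower numbers for stronger inhibition of growth), compound 1 `COc1ccc(CNc2nc([SeH])nc3ccccc23)cc1` gives > 100000 nM, which is a limit of the assay rather than a number. Compound 2 `[SeH]c1nc(NCc2ccccc2)c2ccccc2n1` gives > 100000 nM, also a limit. Going by the values given here, the one step between them, a step that the two limits leave unreadable from compound 1 to compound 2, is therefore unreadable in size, as the limit of > 100000 nM in this assay, at which 2 of the 3 values shown sit, shows. Among the compounds with values here, compound 3 `C[Se]c1nc([Se]C)c2ccccc2n1` gives 33800 nM; no single step links it to compound 1, so its value can only be set beside the others. Compound 4 `COc1ccc(CNc2nc([Se]C)nc3ccccc23)cc1` differs from compound 1 by methyl in place of hydrogen on a selenium. Within the data shown here, no measured step covers this change, so the evidence bearing on it is thin. Compound 4 is expected to show an at least 1.2-fold lower number from compound 1 to compound 4 (0.09 log units; that floor lies within the scatter), with the direction uncertain. The estimate for compound 4 is 80000 nM, within a range from 25000 nM to 250000 nM.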

Compound 4, concentration for total growth inhibition: > 100000 nM
Compound 4 gave a limit, no number (the forecaster's own chance of this, stated with the estimate: 50%); middle value at least 1.2-fold (0.09 log units) away from the limit.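

Compound 1 and compound 4 both give a limit rather than a number, so no size can be read for the step between them: the limit of > 100000 nM in this assay, at which 3 of the 4 values shown sit.

From the compounds shown here alone, whether methyl in place of hydrogen on a selenium changes growth inhibition at all in this assay stays open.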